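Azepan-1-yl versus phenyl on the piperidine sulfonamide

A few compounds are considered here, and "the series" means these few. Any claim that something is new, unique, unknown or untested is made for them only; others in the source may bear on it.

Measured so far:
compound 1 `Cc1cc(C)c(S(=O)(=O)N2CCC(N3CCC(C)CC3)CC2)c(C)c1`: 0.03 nM
compound 2 `Cc1c(C)c(S(=O)(=O)N2CCC(N3CCC(C)CC3)CC2)c(C)c2c1OC(C)(C)C2`: 1.2 nM
compound 3 `Cc1cc(C)c(S(=O)(=O)N2CCC(c3ccccc3)CC2)c(C)c1`: > 5000 nM, a limit of the assay, not a number

All three values come from a functional assay on DLD-1 cells (Homo sapiens) for antiproliferative activity, read by CellTiter-Glo, with a stated time of 72 h; a lower number here means a stronger inhibitor, a higher number a weaker inhibitor. Compound 3 stands apart from compounds 1 and 2: it sits at the limit of > 5000 nM in this assay, at which 1 of the 3 values shown sits, so its position is known only as a limit. Among the compounds with values here, the one measured step that bears on the change at hand is an at least 160000-fold higher number from compound 1 to compound 3 (5.22 log units; beyond the scatter), a large loss on replacing the saturated amine ring by phenyl.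

Compound 4 `Cc1cc(C)c(S(=O)(=O)N2CCC(N3CCCCCC3)CC2)c(C)c1` reverses that kind of change: azepan-1-yl in place of phenyl on a saturated ring carbon. The entering azepan-1-yl is a saturated ring with one nitrogen, as is the 4-methylpiperidin-1-yl of compound 1, though it is seven-membered and carries no methyl. A large step back toward strong inhibition is therefore expected in this assay, its exact size uncertain since compound 3 is only a limit and the azepane is not the same ring as in compound 1. Compound 4 is expected at about 0.3 nM, within 0.03 nM to 5 nM, which would mean a step of an at least 16000-fold lower number from compound 3 to compound 4 (4.22 log units; beyond the scatter).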

Compound 4, half-maximal inhibitory concentration: 5.3 nM
For compound 4 the middle estimate is 18-fold (1.25 log units) below the measured one, outside the stated range (above it).
By their numbers in this assay, from the lowest: compound 1; then compound 2; then compound 4. At a limit, above all of these: compound 3.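

In this assay, a second saturated ring with one nitrogen also restores strong inhibition at this saturated ring carbon, giving an at least 940-fold lower number from compound 3 to compound 4 (2.97 log units; beyond the scatter). The amine ring is not interchangeable, however: azepan-1-yl in place of 4-methylpiperidin-1-yl gives a 180-fold higher number from compound 1 to compound 4 (2.25 log units; beyond the scatter), so the identity of the ring matters as well as its presence. The gain over compound 3 has no upper bound because compound 3 is recorded only as a limit: the limit of > 5000 nM in this assay, at which 1 of the 4 values shown sits.

Ring size and the methyl group both change between the two amines, and piperidin-1-yl without the methyl would separate these two changes. Whether the ring nitrogen or the saturated ring accounts for the gain over phenyl also remains open, a question that cyclohexyl, with carbon in place of that nitrogen, would address.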